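Benzoxaborole propanamide series: aryl amide variation

The source may hold more compounds than are shown below. What is called first, only, known or untested is meant among the compounds shown, and "the series" means these compounds.

Working notes on a set of benzoxaborole propanamides tested in a functional assay on HCT-116 cells (Homo sapiens) for antiproliferative activity, read by MTT assay, with a stated time of 72 h; a higher number here means a weaker inhibitor, a lower number a stronger inhibitor. The acid `O=C(O)CCc1cccc2c1B(O)OC2`, compound 1, gives only a limit, > 100000 nM. The ester-bearing anilide `CCOC(=O)c1ccc(NC(=O)CCc2cccc3c2B(O)OC3)cc1`, compound 2, likewise returns only a limit, > 100000 nM. The isopropyl anilide `CC(C)c1cccc(NC(=O)CCc2cccc3c2B(O)OC3)c1`, compound 3, is the one member with a measured number, 1600 nM, and so stands alone among the shown values; two of the three results sit at the limit of > 100000 nM in this assay, at which 2 of the 3 values shown sit.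

Compound 4, `CSc1ccc(-c2cccc(NC(=O)CCc3cccc4c3B(O)OC4)c2)cc1`, carries 4-(methylsulfanyl)phenyl in place of isopropyl on an aromatic carbon. Within the data shown here, no measured step between two numbered compounds exists in this set, so the size of the change cannot be read from a comparable pair. The expectation is a modest shift, if any, toward stronger inhibition for compound 4, with a step of a 1.6-fold lower number from compound 3 to compound 4 (0.20 log units; within the scatter) from compound 3, which is close to the usual scatter. Compound 4 is therefore estimated at 1000 nM in this assay, with a range of 250 nM to 4000 nM.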

Compound 4, half-maximal inhibitory concentration: 180 nM
For compound 4 the middle estimate is 5.6-fold (0.74 log units) above the measured one, outside the stated range (below it).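

Among these compounds, replacing isopropyl with 4-(methylsulfanyl)phenyl on an aromatic carbon gives an 8.9-fold lower number from compound 3 to compound 4 (0.95 log units; beyond the scatter) in this assay, the first step in this set that can be read. This position, meta to a large group, therefore accepts the larger substituent, with its one six-membered aromatic ring of carbon only, and the number falls rather than being lost. Nothing measured here accounts for the size of this step.

The compounds shown do not separate the effect of the added ring from that of the methylsulfanyl group, and a plain phenyl or a 4-methoxyphenyl at the same place would be needed to tell them apart. On these data alone, it also remains open how an amine or a longer chain on that outer ring would read in this assay.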